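Series notes: compound 3 to compound 4

The source may hold more compounds than are shown below. What is called first, only, known or untested is meant among the compounds shown, and "the series" means these compounds.

In a functional assay on HepG2 cells (Homo sapiens) for inhibition, read by MTT assay (a higher number here means a weaker inhibitor, a lower number a stronger inhibitor), compound 1 `CCc1ccc(C(=O)Nc2ccc(Nc3ncnc4cc(OC)c(OC)cc34)cc2)cc1` gives 72000 nM and compound 2 `COc1cc2ncnc(Nc3ccc(NC(=O)c4ccccc4F)cc3)c2cc1OC` gives 13000 nM, while compound 3 `COc1cc2ncnc(Nc3ccc(NC(=O)c4ccccc4I)cc3)c2cc1OC` gives 33000 nM as the middle of the three numbers. Compound 4 `COc1cc2ncnc(Nc3ccc(NC(=O)c4ccc(C(F)(F)F)cc4)cc3)c2cc1OC` is unmeasured and carries 4-(trifluoromethyl)phenyl in place of 2-iodophenyl on a carbonyl carbon. Two modest steps leave 4-ethylphenyl: 2-iodophenyl gave a 2.2-fold lower number from compound 1 to compound 3 (0.34 log units; beyond the scatter) and 2-fluorophenyl gave a 5.5-fold lower number from compound 1 to compound 2 (0.74 log units; beyond the scatter). Iodo in place of fluoro gave a 2.5-fold higher number from compound 2 to compound 3 (0.40 log units; beyond the scatter) as a further modest step. Among the compounds with values here, no measured step tests trifluoromethyl. A slight lean to a higher number in this assay is expected, resting only on compound 1 at 72000 nM as the sole 4-ethylphenyl case. The estimated step (a 1.4-fold higher number from compound 3 to compound 4 (0.13 log units; within the scatter)) is not expected to clear the scatter. Compound 4 is estimated at 45000 nM (expected range 16000 nM to 120000 nM).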

Compound 4, half-maximal inhibitory concentration: > 100000 nM
Compound 4: only a limit was reported; the forecaster's own chance of this, stated with the estimate: 10%; middle value at least 2.2-fold (0.34 log units) from the limit.
By their numbers in this assay, from the lowest: compound 2; then compound 3; then compound 1. At a limit, above all of these: compound 4.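

In this assay compound 4 is reported only as a limit: the limit of > 100000 nM in this assay, at which 1 of the 4 values shown sits.

On this carbonyl carbon, 4-(trifluoromethyl)phenyl gives an at least 3.0-fold higher number from compound 3 to compound 4 (0.48 log units; beyond the scatter) and an at least 7.6-fold higher number from compound 2 to compound 4 (0.88 log units; beyond the scatter), so the change away from either 2-iodophenyl or 2-fluorophenyl raises the number beyond the scatter. Against 4-ethylphenyl the step is an at least 1.3-fold higher number from compound 1 to compound 4 (0.14 log units; that floor lies within the scatter), so trifluoromethyl and ethyl are not told apart here.

The compounds shown leave open how a phenyl carrying an amine or a carboxylic acid would read on this carbonyl carbon. On these data alone, the true size of each step to compound 4 also stays open: only a limit is known.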